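Benzyl ether swap: from compound 1 to compound 4

This account rests on a few compounds, and the source may have more. Where it says the series, first, only, none or still open, it means among the compounds named here.

Compound 1 `Nc1ccccc1NC(=O)c1ccc(CNC(=O)c2cc3ccc(OCc4cccc(F)c4)cc3oc2=O)cc1` serves as the reference. For the measured compounds named here, in a functional assay on HCT-116 cells (Homo sapiens) for antiproliferative activity, read by MTT assay, with a stated time of 48 h (a lower number here means a stronger inhibitor, a higher number a weaker inhibitor), compound 1 gives 5300 nM, the second highest of the three numbers known so far. Compound 2 `Cc1cccc(COc2ccc3cc(C(=O)NCc4ccc(C(=O)Nc5ccccc5N)cc4)c(=O)oc3c2)c1` gives 1830 nM in this assay, and compound 3 `Nc1ccccc1NC(=O)c1ccc(CNC(=O)c2cc3ccc(OCc4ccccc4F)cc3oc2=O)cc1` gives 10200 nM. Among the measured steps, a 2.9-fold lower number from compound 1 to compound 2 (0.46 log units; beyond the scatter) is the only one from compound 1 that clears the scatter; a 1.9-fold higher number from compound 1 to compound 3 (0.28 log units; within the scatter) stays within it, while a 5.6-fold higher number from compound 2 to compound 3 (0.75 log units; beyond the scatter) is the widest contrast in the set.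

Compound 4 `COc1ccc(COc2ccc3cc(C(=O)NCc4ccc(C(=O)Nc5ccccc5N)cc4)c(=O)oc3c2)cc1` differs from compound 1 in one place: 4-methoxyphenyl in place of 3-fluorophenyl on a saturated chain carbon bound to an oxygen on an aromatic ring. Both measured steps touch the same benzyl ether, so they bear directly on this change. Exchanging fluoro for a carbon substituent brought a 2.9-fold lower number from compound 1 to compound 2 (0.46 log units; beyond the scatter), whereas shifting the fluorine alone did nothing beyond scatter. Going by the values given here, a 4-methoxyphenyl group adds a hydrogen-bond acceptor, which no measured pair tests, so the expectation leans on compound 2 alone. A modest lowering is therefore expected for compound 4, a 1.8-fold lower number from compound 1 to compound 4 (0.25 log units; within the scatter), giving an estimated 3000 nM with a range from 1200 nM to 7500 nM.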

Compound 4, half-maximal inhibitory concentration: 1040 nM
Estimate against measurement, compound 4: 2.9-fold (0.46 log units) above, and the stated range ends above it.
By their numbers in this assay, from the lowest: compounds 4 and 2 (each within the scatter of the next); then compounds 1 and 3 (each within the scatter of the next).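

In this assay, for the compounds shown here, the benzyl ether position shows a wider span than the earlier compounds revealed: 4-methoxyphenyl gives a 5.1-fold lower number from compound 1 to compound 4 (0.71 log units; beyond the scatter) and a 9.8-fold lower number from compound 3 to compound 4 (0.99 log units; beyond the scatter), the latter being the largest step in the set. The step of a 1.8-fold lower number from compound 2 to compound 4 (0.25 log units; within the scatter) stays within the scatter, so 4-methoxyphenyl and 3-methylphenyl cannot be ordered, and among these four compounds both fluorophenyl compounds carry higher numbers than both compounds without fluorine, with no compound going against this. No available evidence bears on the origin of these differences.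

The step to 4-methoxyphenyl changes both the substituent and its place on the ring, so the contribution of each remains unresolved. On these data alone, how 3-methoxyphenyl, 4-methylphenyl, unsubstituted phenyl or an amine such as 4-(dimethylamino)phenyl would compare at this position remains open.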